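This account rests on a few compounds, and the source may have more. Where it says the series, first, only, none or still open, it means among the compounds named here.

In a functional assay on MCF7 cells (Homo sapiens) for antiproliferative activity, read by MTT assay (a higher number here means a weaker inhibitor, a lower number a stronger inhibitor), compound 2 `c1ccc2c(c1)ccn2-c1nc(N2CCNCC2)nc2ccccc12` gives 14.1 ug/mL and holds the lower of the two numbers, while compound 1 `COc1ccc(-c2nc(N3CCNCC3)nc3ccccc23)c(OC)c1` gives 50 ug/mL and the gap lies beyond the scatter. Compound 3 `CN1CCN(c2nc(-n3ccc4ccccc43)c3ccccc3n2)CC1` differs from compound 2 by one change methyl in place of hydrogen on an amine nitrogen in a ring that reads piperazin-1-yl to 4-methylpiperazin-1-yl. Among the compounds with values here, no measured pair shows this change, so no shift beyond the scatter is expected, and no direction can be called with confidence. The expected step is a 1.1-fold higher number from compound 2 to compound 3 (0.05 log units; within the scatter) and stays within the scatter of this assay as far as can be judged. Compound 3 is estimated at 16 ug/mL with an expected range from 7 ug/mL to 35 ug/mL for the coming measurement.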

Compound 3, half-maximal inhibitory concentration: 6 ug/mL
Estimate against measurement, compound 3: 2.7-fold (0.43 log units) above; measured number below the stated range.
By their numbers in this assay, from the lowest: compound 3; then compound 2; then compound 1.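

In this assay, within the data shown here, methyl in place of hydrogen on the amine nitrogen, piperazin-1-yl to 4-methylpiperazin-1-yl, gives a 2.4-fold lower number from compound 2 to compound 3 (0.37 log units; beyond the scatter) and is the first step read at this position. In this pair, the hydrogen on that nitrogen is not required for activity, and the added methyl is tolerated with a modest improvement. Nothing available explains the step.

Going by these compounds, whether a longer chain such as ethyl or propyl on the same nitrogen extends the trend remains open. So does the effect of an acetyl group there.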